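The compounds below may be only part of what the source reports. "The series", "measured", "known", "first", "only" and "open" are said of these compounds alone.

In a functional assay on SEM cells (Homo sapiens) for inhibition, read by MTT assay, with a stated time of 72 h (on this read-out higher numbers stand for weaker inhibition and lower numbers for stronger inhibition), compound 1 (`COc1cccc(/C=C/C(=O)Nc2cc(OC)c(OC)c(OC)c2)c1`) gives 18200 nM and compound 2 (`COc1cc(NC(=O)/C=C/c2cccc(OCc3ccccc3)c2)cc(OC)c1OC`) gives 8500 nM. Compound 3 (`C=C(Br)C(=O)Nc1cccc(/C=C/C(=O)Nc2cccc(F)c2)c1`) gives 620 nM, the lowest of the three numbers and so the strongest inhibition among them.

Compound 4 (`C=C(Br)C(=O)Nc1cccc(/C=C/C(=O)Nc2ccc(OC)cc2)c1`) departs from compound 3 at one place: 4-methoxyphenyl in place of 3-fluorophenyl on an amide-type nitrogen. In words, 4-methoxyphenyl stands in place of 3-fluorophenyl on an amide-type nitrogen.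

Within the data shown here, the only measured step between two compounds that differ in one place is a 2.1-fold lower number from compound 1 to compound 2 (0.33 log units; beyond the scatter). It was modest and concerns a saturated chain carbon bound to an oxygen on an aromatic ring, not the amide-type nitrogen. Among the measured compounds shown here, no measured pair shows what a change of group on that nitrogen does, so the data offer no direct guide. No step beyond the scatter is therefore expected in this assay, in either direction, and the uncertainty stays wide.

The expected change is a 1.0-fold lower number from compound 3 to compound 4 (0.01 log units; within the scatter). Compound 4 is estimated at 600 nM, with an expected range of 200 nM to 1800 nM.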

Compound 4, half-maximal inhibitory concentration: 70 nM
Estimate against measurement, compound 4: 8.6-fold (0.93 log units) above; measured number below the stated range.
By their numbers in this assay, from the lowest: compound 4; then compound 3; then compound 2; then compound 1.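

In this assay, the group on the amide-type nitrogen proves to matter: 4-methoxyphenyl in place of 3-fluorophenyl gives an 8.9-fold lower number from compound 3 to compound 4 (0.95 log units; beyond the scatter), a step beyond the scatter. Among these compounds, this is the first measured change at this position, and it shows that the assay responds to the group carried there, with compound 4 holding the lowest number of the series. The exchange replaces a ring bearing fluorine with one bearing a methoxy group, and no measurement in hand accounts for the difference in inhibition.

The compounds shown do not separate the loss of the fluorine from the arrival of the methoxy group, since a single step changes both. On these data alone, how a plain phenyl on the same nitrogen, or a ring bearing an amine or a longer alkoxy chain, would compare remains open.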